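Imidazole to furan on the aminomethyl arm: solubility expectation

This account rests on a few compounds, and the source may have more. Where it says the series, first, only, none or still open, it means among the compounds named here.

Among the measured compounds shown here, compound 3 `Cc1cc(NCc2ncc[nH]2)n2nc(C)c(-c3ccccc3)c2n1` is the odd one of the three measured members. In a physicochemical assay for solubility, read by HPLC, using the shake flask method, measured as kinetic solubility, with a stated time of 2 h, at pH 7.4 (a lower number here means a less soluble compound, a higher number a more soluble compound), compound 3 returns only a limit, < 5000 nM. That reading sits on (the limit of < 5000 nM in this assay, at which 1 of the 3 values shown sits), so for compound 3 there is no number, only a bound.

The two companions give numbers. In this assay compound 1 `Cc1cc(NCc2ccncc2)n2nc(C)c(-c3ccccc3)c2n1` gives 134000 nM. In this assay compound 2 `Cc1cc(NCc2ncccn2)n2nc(C)c(-c3ccccc3)c2n1` gives 37900 nM. The steps onto compound 3 are both downward: an at least 26-fold lower number from compound 1 to compound 3 (1.42 log units; beyond the scatter) and an at least 7.5-fold lower number from compound 2 to compound 3 (0.87 log units; beyond the scatter); the pyridine-to-pyrimidine change, a 3.5-fold lower number from compound 1 to compound 2 (0.55 log units; beyond the scatter), is the smaller move.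

Compound 4 `Cc1cc(NCc2ccco2)n2nc(C)c(-c3ccccc3)c2n1` has not been measured. It differs from compound 3 by furan-2-yl in place of 1H-imidazol-2-yl on a saturated chain carbon bound to a nitrogen on an aromatic ring. For the measured compounds named here, none of the measured steps involves a furan-2-yl group, so the two steps onto compound 3 show only where the imidazole member lies, not how the furan member will compare with it. With compound 3 itself fixed only at a bound, the step of a number no lower from compound 3 to compound 4 (the limit leaves the size open) can be stated only as an expectation anchored near that bound. Compound 4 is accordingly expected to come in around 5000 nM in this assay, with a plausible span from 1000 nM to 30000 nM, and a real chance that the assay again reports only a limit.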

Compound 4, solubility: < 5000 nM
Compound 4: no number, only a limit; the forecaster's own chance of this, stated with the estimate: 45%; the middle value lies on the limit itself.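

Like compound 3, compound 4 gives only a limit and not a number in this assay: the limit of < 5000 nM in this assay, at which 2 of the 4 values shown sit.

Among the compounds shown here, with furan-2-yl on a saturated chain carbon bound to a nitrogen on an aromatic ring, the readings against the two measured members are an at least 26-fold lower number from compound 1 to compound 4 (1.42 log units; beyond the scatter) and an at least 7.5-fold lower number from compound 2 to compound 4 (0.87 log units; beyond the scatter), so the low end at this position is no longer held by 1H-imidazol-2-yl alone, and it now includes a group with no hydrogen-bond donor. Among the four compounds, only the pyridin-4-yl and pyrimidin-2-yl members give numbers, while both five-membered aromatic rings give limits, and the step between those two limits cannot be read, so no order of furan-2-yl against 1H-imidazol-2-yl follows.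

From the compounds shown here alone, how far compound 3 and compound 4 each lie past the limit stays open, as does whether the two differ at all. Also open, going by these compounds, is whether a morpholine ring or a carboxylic acid at this chain carbon, in place of the aromatic ring, would give a reading that can be compared with compound 1 and compound 2.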